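Purine base variation on a protected bicyclic sulfonate core

This account rests on a few compounds, and the source may have more. Where it says the series, first, only, none or still open, it means among the compounds named here.

The series shares the protected bicyclic core seen in compound 1 `CC(C)(C)[Si](C)(C)OC[C@H]1O[C@@H](n2cnc3cncnc32)[C@H](O[Si](C)(C)C(C)(C)C)[C@]12OS(=O)(=O)C=C2N`, compound 2 `CC(C)(C)[Si](C)(C)OC[C@H]1O[C@@H](n2cnc3c(N)ncnc32)[C@H](O[Si](C)(C)C(C)(C)C)[C@@]12OS(=O)(=O)C=C2N` and compound 3 `COc1ncnc2c1ncn2[C@@H]1O[C@H](CO[Si](C)(C)C(C)(C)C)[C@@]2(OS(=O)(=O)C=C2N)[C@H]1O[Si](C)(C)C(C)(C)C`. In a functional assay on MT4 cells (Homo sapiens) for cytotoxicity (a higher number here means that more compound is tolerated, a lower number that less compound is tolerated), compound 3 gives 21000 nM, a number beyond the scatter above compound 2, which gives 7300 nM, while compound 1 at 13000 nM cannot be separated from it, the step of a 1.6-fold higher number from compound 1 to compound 3 (0.21 log units; within the scatter) lying within the scatter. Compound 4 `CCn1cnc2ncn([C@@H]3O[C@H](CO[Si](C)(C)C(C)(C)C)[C@@]4(OS(=O)(=O)C=C4N)[C@H]3O[Si](C)(C)C(C)(C)C)c2c1=O` carries the change (a group of 12 heavy atoms (7 carbon, 4 nitrogen, 1 oxygen; one five-membered aromatic ring with 2 hetero atoms, one six-membered aromatic ring with 2 hetero atoms) in place of a group of 11 heavy atoms (6 carbon, 4 nitrogen, 1 oxygen; one five-membered aromatic ring with 2 hetero atoms, one six-membered aromatic ring with 2 hetero atoms), on a saturated ring carbon). For the measured compounds named here, no measured step covers this base swap; the only step on the base, from compound 1 to compound 3, stayed within the scatter. On that basis no shift beyond the scatter is expected in this assay, a 1.4-fold lower number from compound 3 to compound 4 (0.15 log units; within the scatter), and compound 4 is estimated at 15000 nM, range 6000 nM to 40000 nM.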

Compound 4, half-maximal cytotoxic concentration: > 150000 nM
Compound 4 gave a limit, no number (the forecaster's own chance of this, stated with the estimate: 15%); at least 10-fold (1.00 log units) between middle value and limit.
By their numbers in this assay, from the lowest: compounds 2, 1 and 3 (each within the scatter of the next, the first and the last beyond it). At a limit, above all of these: compound 4.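

The base on this saturated ring carbon, next to the ring oxygen, can shift the tolerated concentration beyond the scatter, which the methoxy step alone did not show. In this assay, the base change gives an at least 7.1-fold higher number from compound 3 to compound 4 (0.85 log units; beyond the scatter) and an at least 11-fold higher number from compound 1 to compound 4 (1.06 log units; beyond the scatter) for the larger swap from the unsubstituted base. The value of compound 4 is a limit of the assay, not a number: the limit of > 150000 nM in this assay, at which 1 of the 4 values shown sits.

Going by these compounds, the size of the true shift therefore stays open. Also open, on these data alone, is how a chlorine or a longer alkyl chain on the base would read in this assay on the shared core.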